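The source may hold more compounds than are shown below. What is called first, only, known or untested is meant among the compounds shown, and "the series" means these compounds.

Compound 1 `COc1ccc(C2CC(c3ccc(NC(=O)c4cc(Cl)ccc4OC)cc3)=NN2C)cc1`: 93.2%
Compound 2 `COc1ccc(Cl)cc1C(=O)Nc1ccc(C2=NN(C)C(c3ccccc3[N+](=O)[O-])C2)cc1`: 99.5%
Compound 3 `COc1ccc(Cl)cc1C(=O)Nc1ccc(C2=NN(C)C(c3ccc([N+](=O)[O-])cc3)C2)cc1`: 97.4%

In a functional assay on the whole organism (strain albino) with Rattus norvegicus as the target, read by paw edema, with stated times of 1 h and 4 h, at a dose of 50 mg/kg by the oral route (on this read-out lower numbers stand for a weaker effect and higher numbers for a stronger effect at the one dose given), compound 1 gives 93.2%, the lowest of the three numbers, yet the steps of a number 4.2 percentage points higher from compound 1 to compound 3 (within the scatter) and a number 6.3 percentage points higher from compound 1 to compound 2 (within the scatter) are within the scatter, so the three compounds cannot be ranked against each other. Compound 4 `COc1ccc(C2CC(c3ccc(NC(=O)c4cc(Cl)ccc4OC)cc3)=NN2)cc1` differs from compound 1 by hydrogen in place of methyl on an amine nitrogen in a ring. For the measured compounds named here, no measured step touches this amine nitrogen in a ring; the measured steps exchange groups on a saturated ring carbon or on an aromatic carbon, and each of them stayed within the scatter. With all three measured numbers sitting close together, no step beyond the scatter is expected for compound 4, a number 5.2 percentage points lower from compound 1 to compound 4 (within the scatter). Compound 4 is therefore estimated at 88%, in the range 68% to 99%.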

Compound 4, a percentage reported as activity, at one dose (the size of the read-out at that dose, not a potency): 89%
Estimate against measurement, compound 4: 1 percentage points below; the range from low to high includes it.
By their numbers in this assay, from the lowest: compounds 4, 1, 3 and 2 (each within the scatter of the next, the first and the last beyond it).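

For the compounds shown here, this is the first measured change at the amine nitrogen in a ring: in this assay, hydrogen in place of methyl gives a number 4.2 percentage points lower from compound 1 to compound 4 (within the scatter). So on this read-out, at the one dose given, the methyl on this nitrogen can be replaced by hydrogen without a step beyond the usual scatter. No available evidence explains this result. Still open, from the compounds shown here alone, is how a longer chain such as ethyl or propyl, or an acetyl group, would read at this nitrogen. Also open, going by these compounds, is whether the same exchange would read alike with 2-nitrophenyl or 4-nitrophenyl on the saturated ring carbon.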